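This account rests on a few compounds, and the source may have more. Where it says the series, first, only, none or still open, it means among the compounds named here.

Values so far in a functional assay on MCF7 cells (Homo sapiens) for antiproliferative activity, read by MTT assay, with a stated time of 48 h; on this read-out higher numbers stand for weaker inhibition and lower numbers for stronger inhibition:

- Compound 1 `c1ccc(-c2nn(-c3ccccc3)cc2-c2nc3ccccc3[nH]2)cc1` gives 3190 nM
- Compound 2 `Clc1ccc2[nH]c(-c3cn(-c4ccccc4)nc3-c3ccccc3)nc2c1` gives 1960 nM
- Compound 3 `FC(F)(F)c1ccc2[nH]c(-c3cn(-c4ccccc4)nc3-c3ccccc3)nc2c1` gives 2660 nM

Compound 2 cannot be told apart from the other two on these numbers. Its value of 1960 nM is linked to them by a 1.6-fold lower number from compound 1 to compound 2 (0.21 log units; within the scatter) and a 1.4-fold higher number from compound 2 to compound 3 (0.13 log units; within the scatter), and repeat measurements of a single compound can differ by as much.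

Compound 4 `COc1ccc(-c2nn(-c3ccccc3)cc2-c2nc3cc(Cl)ccc3[nH]2)cc1` has not yet been measured. It differs from compound 2 at one place: methoxy in place of hydrogen on an aromatic carbon. This is methoxy in place of hydrogen on an aromatic carbon, turning a phenyl into a 4-methoxyphenyl.

Within the data shown here, no measured step involves methoxy or changes that phenyl, so the evidence is only indirect. The closest guides are changes made elsewhere on the molecule: chloro in place of hydrogen gave a 1.6-fold lower number from compound 1 to compound 2 (0.21 log units; within the scatter), and trifluoromethyl in place of hydrogen gave a 1.2-fold lower number from compound 1 to compound 3 (0.08 log units; within the scatter). Both stayed small, so no shift beyond the scatter is expected in this assay, and the data favour neither direction. The expected change is a 1.1-fold lower number from compound 2 to compound 4 (0.04 log units; within the scatter). For compound 4 the estimated value is 1800 nM, with an expected range from 600 nM to 5000 nM.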

Compound 4, half-maximal inhibitory concentration: 1760 nM
Estimate against measurement, compound 4: 1.0-fold (0.01 log units) above; the measured number falls inside the stated range.
By their numbers in this assay, from the lowest: compounds 4, 2, 3 and 1 (each within the scatter of the next).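

Among these compounds, compound 4 is the first compound here in which this phenyl differs, as all the earlier compounds carry it unsubstituted, so it gives the first reading at this position. In this assay replacing a hydrogen with methoxy on this aromatic carbon, para to a large group, gives a 1.1-fold lower number from compound 2 to compound 4 (0.05 log units; within the scatter) and therefore cannot be told apart from repeat-measurement noise. The phenyl of compound 2 can thus become a 4-methoxyphenyl, gaining a carbon, an oxygen and a hydrogen-bond acceptor, without a measurable shift in this assay, and no measurement shown offers any explanation for that.

This single pair says nothing about whether a very different group at the same place, such as an amine, a carboxylic acid or a longer alkoxy chain, would also leave the number within the scatter. It also leaves open whether methoxy would behave the same way without the chloro of compound 2, and whether the result holds beyond these cells.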